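The compounds below may be only part of what the source reports. "The series", "measured", "known", "first", "only" and "open" are said of these compounds alone.

Measured so far:
compound 1 `Fc1ccc(Nc2cc3[nH]c(Nc4ccc(N5CCN(C6CC6)CC5)cn4)nc3cn2)cc1C(F)(F)F` gives 23000 nM
compound 2 `CC(C)(C)N1CCN(c2ccc(Nc3nc4cnc(Nc5cccc(C(F)(F)F)c5)cc4[nH]3)nc2)CC1` gives 99000 nM

In an ADME assay on CHO cells (Cricetulus griseus) for cytotoxicity, read by MTT assay (a lower number here means that less compound is tolerated, a higher number that more compound is tolerated), compound 2 stands highest of the two, and its gap to compound 1 lies beyond the scatter. Compound 3 `C[C@H]1CN(c2ccc(Nc3nc4cnc(Nc5cccc(C(F)(F)F)c5)cc4[nH]3)nc2)CCN1` differs from compound 2 in one place (3-methylpiperazin-1-yl in place of 4-(tert-butyl)piperazin-1-yl on an aromatic carbon), carrying 3-methylpiperazin-1-yl in place of 4-(tert-butyl)piperazin-1-yl on an aromatic carbon. For the measured compounds named here, no measured pair isolates this change, so the step is a judgement. A moderate fall in this assay is expected, somewhat beyond the scatter, with compound 1 at 23000 nM as the only lower reference. The expected step is a 2.5-fold lower number from compound 2 to compound 3 (0.39 log units; beyond the scatter). Compound 3 is estimated at 40000 nM, within an expected range from 12000 nM to 100000 nM.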

Compound 3, half-maximal cytotoxic concentration: 25000 nM
Estimate against measurement, compound 3: 1.6-fold (0.20 log units) above; the range from low to high includes it.
By their numbers in this assay, from the lowest: compounds 1 and 3 (each within the scatter of the next); then compound 2.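

In this assay, for the compounds shown here, 3-methylpiperazin-1-yl in place of 4-(tert-butyl)piperazin-1-yl gives a 4.0-fold lower number from compound 2 to compound 3 (0.60 log units; beyond the scatter) on this aromatic carbon, the first single-place step here, so the group at this position does affect how much compound is tolerated. The entering group has fewer heavy atoms, adds a hydrogen-bond donor and brings a defined stereocentre, and this one pair cannot separate these differences. No measurement on hand explains the step. Going by these compounds, how a morpholine or an unsubstituted piperazine would read in this assay remains open.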